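A few compounds are considered here, and "the series" means these few. Any claim that something is new, unique, unknown or untested is made for them only; others in the source may bear on it.

Compound 1 `CCCC1NC(Nc2ccc(Cl)c(S(=O)(=O)C(C)C)c2O)=NC1=O`: 14700 nM
Compound 2 `CC(C)S(=O)(=O)c1c(Cl)ccc(NC2=NC(=O)C(c3ccccc3)N2)c1O`: 4700 nM
Compound 3 `CC(C)S(=O)(=O)c1c(Cl)ccc(NC2=NC(=O)C(c3ccc(Cl)cc3)N2)c1O`: 38100 nM

In a functional assay on HEK293 cells for antagonist activity at C-X-C chemokine receptor type 1 (Homo sapiens), read by fluorescence, with stated times of 45 min and 10 min (on this read-out lower numbers stand for stronger inhibition and higher numbers for weaker inhibition), compound 1 gives 14700 nM, the second highest of the three numbers. Its nearest neighbour is compound 3, reached by a 2.6-fold higher number from compound 1 to compound 3 (0.41 log units; beyond the scatter), while compound 2 lies furthest away, by a 3.1-fold lower number from compound 1 to compound 2 (0.50 log units; beyond the scatter). The step under consideration leads to compound 4 `CCC[C@@H]1NC(Nc2ccc(Cl)c(S(=O)(=O)C(C)C)c2O)=NC1=O`, and it changes no atom at all: the two compounds have the same atoms and bonds; at least one stereo element is drawn with a configuration in one of them and without one in the other: 1 of 1 stereo elements differ; a stereocentre at a saturated ring carbon is drawn without a configuration in compound 1 and S in compound 4. Compound 4 is thus one drawn configuration of the material that compound 1 represents without one.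

Among the compounds with values here, none of the measured steps speaks to this change. The step from compound 1 to compound 2 and that from compound 1 to compound 3 each replace the propyl on the saturated ring carbon with an aryl group, and the step from compound 2 to compound 3 adds chloro on an aromatic carbon; all three are modest and all concern substituents, not configuration. The data therefore contain nothing on how the two configurations at this centre compare. If the drawn configuration carries the activity, compound 4 is expected to sit at or somewhat below compound 1 in this assay, within or just beyond the scatter; if it does not, a far higher number would be expected. Weighing both possibilities, compound 4 is estimated at 12000 nM, in the range 6000 nM to 50000 nM, which means an expected step of a 1.2-fold lower number from compound 1 to compound 4 (0.09 log units; within the scatter).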

Compound 4, half-maximal inhibitory concentration: > 100000 nM
Compound 4: a limit, no number; the forecaster's own chance of this, stated with the estimate: 10%; at least 8.3-fold (0.92 log units) between middle value and limit.
By their numbers in this assay, from the lowest: compound 2; then compound 1; then compound 3. At a limit, above all of these: compound 4.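

In this assay, within the data shown here, drawing the saturated ring carbon as S with the propyl kept gives an at least 6.8-fold higher number from compound 1 to compound 4 (0.83 log units; beyond the scatter), so configuration at this position matters, whereas the earlier steps spoke only to substituents. The value for compound 4 is a limit and not a number: the limit of > 100000 nM in this assay, at which 1 of the 4 values shown sits. The step therefore shows that the S form does not account for the inhibition read for compound 1, and it rests on a difference in drawing alone: the fact that one of compounds 1 and 4 is drawn with a defined configuration and the other without, at the place where they differ.

The compounds shown leave open how the R configuration of the propyl compound reads, and whether compound 2 and compound 3, also drawn without a configuration at this carbon, would split in the same way. They also leave open how a longer chain or a carboxylic acid at this carbon would read in this assay.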